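The source may hold more compounds than are shown below. What is called first, only, known or untested is meant among the compounds shown, and "the series" means these compounds.

The series shares one core, seen in compound 1 `COC(=O)c1ccc(NCc2cncn2Cc2cccc(Cl)c2)cc1-c1ccccc1`, compound 2 `COC(=O)c1ccc(NCc2cncn2Cc2ccc(OC)cc2)cc1-c1ccccc1` and compound 3 `COC(=O)c1ccc(NCc2cncn2Cc2cccc(C(C)(C)C)c2)cc1-c1ccccc1`; the three differ only in the group carried on the saturated chain carbon bound to the aromatic nitrogen. In a toxicity assay on NIH3T3 cells (Mus musculus) for cytotoxicity, read by resazurin assay (on this read-out lower numbers stand for an effect already at smaller amounts and higher numbers for an effect only at larger amounts of compound), compound 1 gives > 10000 nM, which is a limit of the assay and not a number. For compound 2 the entry in this assay reads "not determined" (no result reported). Compound 3 in this assay gives > 1000 nM, again a limit rather than a number. Within the data shown here, the only step between measured compounds, a step that the two limits leave unreadable from compound 1 to compound 3, cannot be given a size because the limit of > 1000 nM in this assay, at which 1 of the 3 values shown sits, and the limit of > 10000 nM in this assay, at which 1 of the 3 values shown sits, are both limits and not numbers. Compound 3 therefore stands on a limit alone, with one further limit and one entry without a number beside it. Compound 4 `COC(=O)c1ccc(NCc2cncn2Cc2ccccc2[N+](=O)[O-])cc1-c1ccccc1` differs from compound 3 by 2-nitrophenyl in place of 3-(tert-butyl)phenyl on a saturated chain carbon bound to an aromatic nitrogen. Among the measured compounds shown here, no measured step bears on this change, and the one step available offers no size; no step beyond the usual scatter is expected in this assay in either direction, and the most likely outcome is yet another limit. The step expected from compound 3 to compound 4 is a step that the limit leaves unreadable from compound 3 to compound 4. Compound 4 is expected to give 20000 nM in this assay, within 3000 nM to 100000 nM.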

Compound 4, half-maximal effective concentration: 10000 nM
Estimate against measurement, compound 4: 2.0-fold (0.30 log units) above, and the stated range covers the measured number.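

In this assay compound 4 gives 10000 nM as a plain number. No other entry in this series holds one. Compound 4 thus shows that a reading can be obtained with 2-nitrophenyl on a saturated chain carbon bound to an aromatic nitrogen, in a group that, unlike the carbon-only 3-(tert-butyl)phenyl it replaces, carries nitrogen and oxygen and has hydrogen-bond acceptors. With 2-nitrophenyl in place of 3-chlorophenyl, the data show a number no higher from compound 1 to compound 4 (the limit leaves the size open). The step to compound 4 from compound 3 cannot be read, however, so this number marks one fixed point at this place and gives no size for either change.

On these data alone, whether the reading belongs to the nitro group itself or to 2-nitrobenzyl as a whole stays open, as does what an amine or a carboxylic acid on the same benzyl group would give in this assay at this place. Also open, as far as these compounds go, is how far the true values behind the limits of compound 1 and compound 3 lie from the number of compound 4.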